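A Sulfonamide Gives Way to a Hydroxy Group

A few compounds are considered here, and "the series" means these few. Any claim that something is new, unique, unknown or untested is made for them only; others in the source may bear on it.

Compound 1 `COc1ccc(-c2c(C)nc3c(N4CC[C@@H](NS(=O)(=O)C(C)C)C4)cc(C)nn23)cc1OC` was tested in an ADME assay on microsomes from liver (Homo sapiens) for metabolic stability, read by LC-MS, with NADPH named in the record, with a stated time of 60 min, tested at 1 uM, in the absence of a further agent (on this read-out lower numbers stand for a less stable compound and higher numbers for a more stable compound), where compound 1 gives > 95%, a limit of the assay rather than a number. Compound 2 `COc1ccc(-c2c(C)nc3c(N4CC[C@@H](NS(=O)(=O)c5ccc(NC(C)=O)cc5)C4)cc(C)nn23)cc1OC` also sits at a limit, > 95%. Compound 3 `COc1ccc(-c2c(C)nc3c(N4CC[C@@H](NS(=O)(=O)c5ccc(C(C)=O)cc5)C4)cc(C)nn23)cc1OC` likewise gives > 95%, again a limit. The steps a step that the two limits leave unreadable from compound 1 to compound 2, a step that the two limits leave unreadable from compound 1 to compound 3 and a step that the two limits leave unreadable from compound 2 to compound 3 cannot be sized, since (the limit of > 95% in this assay, at which 3 of the 3 values shown sit). Compound 4 `COc1ccc(-c2c(C)nc3c(N4CC[C@@H](O)C4)cc(C)nn23)cc1OC` differs from compound 1 by hydroxy in place of (isopropylsulfonyl)amino on a saturated ring carbon. Going by the values given here, none of the measured steps touches this change, and none yields a readable size. Compound 4 is nonetheless expected to remain high, with an estimated 90% within 70% to 100%. The expected step is a number at least 5 percentage points lower from compound 1 to compound 4 (that floor lies within the scatter), though a limit may again be reported.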

Compound 4, percent of the compound remaining: > 95%
Compound 4 gave a limit, no number; the forecaster's own chance of this, stated with the estimate: 50%; middle value at least 5 percentage points from the limit.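

No size can be read for the change from compound 1 to compound 4, because both values are limits: the limit of > 95% in this assay, at which 4 of the 4 values shown sit. In this assay the compounds shown leave open how far hydroxy and (isopropylsulfonyl)amino truly differ.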